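The source may report more compounds than this note shows. Statements on the series, on what has been measured and on what is new or still open speak of the compounds shown alone.

Two compounds of the series carry the same core and differ only in the amine on the aromatic carbon that sits next to the ring nitrogen. Compound 1 `CCCN(CCC)c1nc(C(F)(F)F)ccc1CNC(=O)C(C)c1ccc(NS(C)(=O)=O)c(F)c1` gives 14.7 nM in a functional assay on CHO-K1 cells for antagonist activity at transient receptor potential cation channel subfamily V member 1 (Homo sapiens), read by FLIPR; a lower number here means a stronger inhibitor, a higher number a weaker inhibitor. Compound 2 `CC(C(=O)NCc1ccc(C(F)(F)F)nc1N1CCCCCC1)c1ccc(NS(C)(=O)=O)c(F)c1` gives 25.1 nM in this assay. Among the measured compounds shown here, the single step between them, a 1.7-fold higher number from compound 1 to compound 2 (0.23 log units; within the scatter), is within the scatter, so the two numbers cannot be separated; the value of compound 2 stands within the scatter of the value of compound 1 and is the only neighbour it has.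

Compound 3 `CC(C(=O)NCc1ccc(C(F)(F)F)nc1N1CCCCCCC1)c1ccc(NS(C)(=O)=O)c(F)c1` is not yet measured. Relative to compound 2 the change is a group of 8 heavy atoms (7 carbon, 1 nitrogen; one eight-membered non-aromatic ring with 1 hetero atom) in place of a group of 7 heavy atoms (6 carbon, 1 nitrogen; one seven-membered non-aromatic ring with 1 hetero atom), on an aromatic carbon. For the measured compounds named here, the only measured step that bears on it is a 1.7-fold higher number from compound 1 to compound 2 (0.23 log units; within the scatter), which exchanged the amine at the same aromatic carbon without leaving the scatter. On that basis no step beyond the scatter is expected in this assay for the further widening of the ring, and the expected step is a 1.4-fold higher number from compound 2 to compound 3 (0.14 log units; within the scatter). For compound 3 the estimated value in this assay is 35 nM, with a range from 12 nM to 100 nM.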

Compound 3, half-maximal inhibitory concentration: 27.8 nM
Estimate against measurement, compound 3: 1.3-fold (0.10 log units) above, within the range that was stated.
By their numbers in this assay, from the lowest: compounds 1, 2 and 3 (each within the scatter of the next).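

The eight-membered ring in place of azepan-1-yl on this aromatic carbon, next to the ring nitrogen, gives a 1.1-fold higher number from compound 2 to compound 3 (0.04 log units; within the scatter) in this assay and so adds a second ring size that cannot be separated from the first. Among the compounds shown here, the open-chain dipropylamino group and the eight-membered ring, the two amines furthest apart in heavy-atom count and the one pair here that sets a chain against the larger ring, give a 1.9-fold higher number from compound 1 to compound 3 (0.28 log units; within the scatter) and also remain unseparated, so the three amines read as one group with no order among them and the series so far shows no dependence on the amine at this carbon. No measurement in hand accounts for this flat result and the numbers alone give no explanation for it.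

The compounds shown hold only large, uncharged amines with no further hetero atom in the ring, so it remains open whether the same flat reading would hold for a smaller ring such as pyrrolidin-1-yl or for morpholin-4-yl. Equally open, from the compounds shown here alone, is whether an amine carrying a hydroxyl group, or a shorter chain such as dimethylamino, would stay within the scatter of these three.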